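The compounds below may be only part of what the source reports. "The series", "measured", "known", "first", "only" and "open" are said of these compounds alone.

Values in an ADME assay on HeLa Rh cells (Homo sapiens) for cytotoxicity, read by microscopy; on this read-out higher numbers stand for lower toxicity in this test and lower numbers for higher toxicity in this test:

compound 1 `COc1cc(CC(O)c2ccc(-c3ccc(C(F)(F)F)cc3)cc2)c([N+](=O)[O-])cc1OC`: 4100 nM
compound 2 `COc1cc(CC(O)c2ccc(-c3ccc(C)cc3)cc2)c([N+](=O)[O-])cc1OC`: 4700 nM
compound 3 `COc1cc(CC(O)c2ccc(-c3cccnc3)cc2)c([N+](=O)[O-])cc1OC`: only a limit of the assay, > 263000 nM

Compound 1 holds the lowest of the two plain numbers; its nearest neighbour is compound 2, with a 1.1-fold higher number from compound 1 to compound 2 (0.06 log units; within the scatter). Compound 3 sits at the limit of > 263000 nM in this assay, at which 1 of the 3 values shown sits.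

The step to compound 4 `COc1cc(CC(O)c2ccc(-c3cccs3)cc2)c([N+](=O)[O-])cc1OC` is thiophen-2-yl in place of 4-(trifluoromethyl)phenyl on an aromatic carbon. The measured steps that bear on it are the two in which the six-membered carbon-only ring was exchanged for a ring holding a hetero atom: an at least 64-fold higher number from compound 1 to compound 3 (1.80 log units; beyond the scatter) and an at least 55-fold higher number from compound 2 to compound 3 (1.74 log units; beyond the scatter), both large, both ending at a limit. The exchange of trifluoromethyl for methyl, a 1.1-fold higher number from compound 1 to compound 2 (0.06 log units; within the scatter), stayed within the scatter. Compound 4 brings in a five-membered ring with one hetero atom, smaller than the ring that enters in compound 3, so an increase is expected in this assay, though how far it goes is uncertain. For compound 4 the expected step is a 4.9-fold higher number from compound 1 to compound 4 (0.69 log units; beyond the scatter), and the estimate for compound 4 in this assay is 20000 nM, between 4000 nM and 150000 nM.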

Compound 4, half-maximal cytotoxic concentration: 11000 nM
Compound 4: middle estimate off by 1.8-fold (0.26 log units), on the high side; the range from low to high includes it.
By their numbers in this assay, from the lowest: compounds 1 and 2 (each within the scatter of the next); then compound 4. At a limit, above all of these: compound 3.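

In this assay, within the data shown here, a ring with a hetero atom at this position does not by itself bring a step as large as the one to compound 3: a 2.7-fold higher number from compound 1 to compound 4 (0.43 log units; beyond the scatter) and a 2.3-fold higher number from compound 2 to compound 4 (0.37 log units; beyond the scatter), both modest. The two hetero-atom rings also differ from each other, with an at least 23-fold lower number from compound 3 to compound 4 (1.37 log units; beyond the scatter), so among these compounds the result depends on which ring enters, not only on the loss of the six-membered carbon-only ring. Compound 3 is still a limit of the assay, which makes that gap a bound rather than a measured size: the limit of > 263000 nM in this assay, at which 1 of the 4 values shown sits.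

Still open, on these data alone, is whether ring size or the kind of hetero atom separates compound 3 from compound 4. Furan-2-yl and pyridin-4-yl at this position, or a phenyl ring carrying a carboxylic acid or an amine, would bear on that question.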